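The compounds below may be only part of what the source reports. "The series", "measured", "known", "first", "only" and "open" are said of these compounds alone.

Compound 1 `CCOc1ccccc1-c1ncnc2c1cnn2CCN1CCCCC1` and compound 2 `COc1ccc(-c2ncnc3c2cnn3CCN2CCCCC2)cc1` share one core and differ only in the group attached to it. In an assay on HEK293 cells for displacement of a labelled ligand from Sigma non-opioid intracellular receptor 1 (Homo sapiens), read by scintillation counting, with a stated time of 120 min (a higher number here means a weaker inhibitor, a lower number a stronger inhibitor), compound 1 gives 300 nM; in this assay compound 2 gives 531 nM, the higher of the two numbers, though the gap to compound 1 lies within the scatter, so no order between the two is claimed. Compound 3 `Cc1ccncc1-c1ncnc2c1cnn2CCN1CCCCC1` is not yet measured; it has 4-methylpyridin-3-yl in place of 4-methoxyphenyl on an aromatic carbon. Within the data shown here, no measured pair shows a comparable change. The step of a 1.4-fold higher number from compound 2 to compound 3 (0.15 log units; within the scatter) is expected to be small, toward a weaker inhibitor if anything. Compound 3 is estimated at 750 nM, within 250 nM to 2200 nM.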

Compound 3, inhibition constant: 707 nM
The estimate for compound 3 lay 1.1-fold (0.03 log units) above the measured number; the range from low to high includes it.
By their numbers in this assay, from the lowest: compounds 1, 2 and 3 (each within the scatter of the next, the first and the last beyond it).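

Exchanging 4-methoxyphenyl for 4-methylpyridin-3-yl on this aromatic carbon of the shared core gives a 1.3-fold higher number from compound 2 to compound 3 (0.12 log units; within the scatter) in this assay. Among these compounds, this is the first measured single-place change, and it shows that a six-membered aromatic ring with a hetero atom can replace one of carbon only here without a step beyond the scatter. This one pair sets no trend for other groups at this position.

On these data alone, whether an amine or a carboxylic acid on this ring would give a step beyond the scatter stays open. No independent evidence on hand bears on this step.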